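A Fluorine Added to the Pyrimidine of Compound 1

This account rests on a few compounds, and the source may have more. Where it says the series, first, only, none or still open, it means among the compounds named here.

This account concerns three measured compounds and a fourth that awaits measurement. In a functional assay on cells for agonist activity at Glucose-dependent insulinotropic receptor (Homo sapiens), read by a luciferase reporter, with a stated time of 4 h (on this read-out lower numbers stand for smaller maximal responses and higher numbers for larger maximal responses), compound 1 `CS(=O)(=O)c1ccc2c(c1)CCN2c1ncnc2c(C3CCN(c4ncccn4)CC3)coc12` gives 196%, the highest of the three numbers. Compound 2 `Cn1cc(C2CCN(C(=O)OC(C)(C)C)CC2)c2ncnc(Nc3ccc(S(C)(=O)=O)cc3F)c21`, built on a different core, gives 3% in this assay, a gap far beyond the usual scatter. Compound 3 `CC(C)(C)OC(=O)N1CCC(c2csc3c(Nc4ccc(S(C)(=O)=O)cc4F)ncnc23)CC1`, again on another core, gives 82% in this assay, also beyond the scatter below compound 1. No two of these compounds differ in a single place, so no step between measured compounds is known, and the two lower numbers say only that the core of compound 1 carries the largest response here.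

Compound 4 `CS(=O)(=O)c1ccc2c(c1)CCN2c1ncnc2c(C3CCN(c4ncc(F)cn4)CC3)coc12` keeps everything of compound 1 apart from one change: fluoro in place of hydrogen on an aromatic carbon. The change sits on the pyrimidin-2-yl group, which becomes 5-fluoropyrimidin-2-yl.

Within the data shown here, no measured pair shows what this change does. The writer therefore expects the step from compound 1 to compound 4, a number 11 percentage points lower from compound 1 to compound 4 (beyond the scatter), to be small, most likely within the usual scatter, with a slight lean downward. Compound 4 is expected to give about 185%, with a range from 130% to 230%.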

Compound 4, largest response reached (Emax), in percent of the reference or control that the assay uses: 229%
Compound 4: middle estimate off by 44 percentage points, on the low side; the measured number falls inside the stated range.
By their numbers in this assay, from the lowest: compound 2; then compound 3; then compound 1; then compound 4.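

In this assay, among these compounds, replacing hydrogen with fluoro on the pyrimidine, which turns pyrimidin-2-yl into 5-fluoropyrimidin-2-yl, gives a number 33 percentage points higher from compound 1 to compound 4 (beyond the scatter) and provides the first reading of a single change in this set. Among the compounds shown here, the earlier compounds could not show this, since none of them differs from another in only one place and their numbers could only be set against each other across different cores. The step shows that this aromatic carbon, para to a large group and two atoms from the ring nitrogen, is a place where one added fluorine atom can raise the maximal response beyond the usual scatter, even from the highest number among the first three compounds. Nothing available accounts for the rise, so its cause stays unknown.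

As far as these compounds go, it remains open whether chloro, methyl, a nitrile or an amine on the same carbon would raise the response, hold it or lower it. A single pair also cannot say whether fluoro at this place would have a similar effect on a core other than that of compound 1.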